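Sulfonyl aryl variation on the shared core: toward compound 4

The source may hold more compounds than are shown below. What is called first, only, known or untested is meant among the compounds shown, and "the series" means these compounds.

Compound 1 `COc1ccc(S(=O)(=O)c2cnc3cc(F)ccc3c2N2CCC(C)CC2)cc1OC`: 83%
Compound 2 `COc1ccc(S(=O)(=O)c2cnc3cc(F)ccc3c2N2CCC(C)CC2)cc1`: 90%
Compound 3 `Cc1ccc(S(=O)(=O)c2cnc3cc(F)ccc3c2N2CCC(C)CC2)cc1Cl`: 93%

Of the compounds shown here, three sharing the core of compound 1 have been measured in an assay on isolated protein for displacement of a labelled ligand from metabotropic glutamate receptor 5 (Homo sapiens), with a stated time of 60 min, tested at 1 uM; on this read-out lower numbers stand for less inhibition and higher numbers for more inhibition at the one concentration tested (going by the name of the read-out). Compound 3 has the highest of the three numbers, yet its gaps to compound 2 and to compound 1 both lie within the scatter, so no order among the three can be drawn from these values.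

Compound 4 `CC1CCN(c2c(S(=O)(=O)c3cccc(C#N)c3)cnc3cc(F)ccc23)CC1` is not yet measured. Relative to compound 3 the change is 3-cyanophenyl in place of 3-chloro-4-methylphenyl on a sulfonyl sulfur. Two measured steps alter the same aryl group on the sulfonyl sulfur: a number 10 percentage points higher from compound 1 to compound 3 (within the scatter) and a number 3 percentage points higher from compound 2 to compound 3 (within the scatter), each within the scatter. A third step, a number 7 percentage points higher from compound 1 to compound 2 (within the scatter), also stays within the scatter. For the measured compounds named here, none of the measured aryl groups carries a nitrile, so that part of the change has no precedent in this set.

Resting on the two sulfonyl-aryl swaps, a step of a number 8 percentage points lower from compound 3 to compound 4 (within the scatter) is expected, nothing beyond the scatter. Compound 4 is therefore estimated at 85%, with a range from 65% to 97%.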

Compound 4, a percentage reported as inhibition, at one concentration (the size of the read-out at that concentration, not a potency): 92%
For compound 4 the middle estimate is 7 percentage points below the measured one; the range from low to high includes it.
By their numbers in this assay, from the lowest: compounds 1, 2, 4 and 3 (each within the scatter of the next).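

With a nitrile on the aryl group at the sulfonyl sulfur, this assay gives a number 1 percentage points lower from compound 3 to compound 4 (within the scatter) and a number 2 percentage points higher from compound 2 to compound 4 (within the scatter) and a number 9 percentage points higher from compound 1 to compound 4 (within the scatter) as the three new steps. For the compounds shown here, this position therefore accepts 3-cyanophenyl without a step that can be told from the scatter, something the earlier compounds, none of which carries a nitrile, could not show. Nothing available bears on why the number holds at this position.

All four numbers come from one concentration and lie within the scatter of their neighbours, so any difference in potency among these aryl groups remains unresolved. Also open, as far as these compounds go, is how the same position responds to an aryl group carrying a carboxylic acid or an amine, or to a saturated ring on the sulfonyl sulfur.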